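Working notes: chloro in place of methyl

This account rests on a few compounds, and the source may have more. Where it says the series, first, only, none or still open, it means among the compounds named here.

Values from an ADME assay on microsomes from liver (Homo sapiens) for metabolic stability, with a stated time of 10 min, tested at 1 uM (on this read-out lower numbers stand for a less stable compound and higher numbers for a more stable compound), stand as follows
- compound 1 `COc1c(-c2ccc(C(F)(F)F)cc2Cl)ccc2nn([C@@H](CC(C)C)c3ccc(C(=O)NCCC(=O)O)cc3)cc12` gives 89%
- compound 2 `Cc1cc(C(F)(F)F)ccc1-c1cc2cnn([C@@H](CC(C)C)c3ccc(C(=O)NCCC(=O)O)cc3)c2cc1C` gives 81%
- compound 3 `Cc1cc(C(F)(F)F)ccc1-c1cc2cn([C@@H](CC(C)C)c3ccc(C(=O)NCCC(=O)O)cc3)nc2cc1C` gives 57%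

Compound 2 lies within the scatter of compound 1 and beyond the scatter above compound 3. Compound 4 `Cc1cc2c(cnn2[C@@H](CC(C)C)c2ccc(C(=O)NCCC(=O)O)cc2)cc1-c1ccc(C(F)(F)F)cc1Cl` is not yet measured. It replaces the 2-methyl-4-(trifluoromethyl)phenyl of compound 2 with 2-chloro-4-(trifluoromethyl)phenyl chloro in place of methyl on an aromatic carbon on an otherwise unchanged structure. Among the measured compounds shown here, no measured pair isolates this change. Compound 1 also carries 2-chloro-4-(trifluoromethyl)phenyl and gives 89% on a different core. The expected step of a number 3 percentage points higher from compound 2 to compound 4 (within the scatter) is a small rise that stays within the scatter. The value expected for compound 4 is 84% with an estimated range of 72% to 95% for now.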

Compound 4, percent of the compound remaining: 62%
Estimate against measurement, compound 4: 22 percentage points above; the whole stated range lies above it.
By their numbers in this assay, from the lowest: compounds 3 and 4 (each within the scatter of the next); then compounds 2 and 1 (each within the scatter of the next).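

In this assay the swap of 2-methyl-4-(trifluoromethyl)phenyl to 2-chloro-4-(trifluoromethyl)phenyl gives a number 19 percentage points lower from compound 2 to compound 4 (beyond the scatter) on an otherwise unchanged structure. This single-atom change on an aromatic carbon, with no difference in hydrogen-bond donors, acceptors or net charge, shows that methyl and chloro are not interchangeable at this position on this read-out. No available data account for the step.

From the compounds shown here alone, whether fluoro, methoxy or a nitrile here would stay level with compound 2 remains open. So does whether the same step recurs on another core.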